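Moving the imidazole attachment point in an acylguanidine

The source may hold more compounds than are shown below. What is called first, only, known or untested is meant among the compounds shown, and "the series" means these compounds.

Measured so far:
compound 1 `CN(C)Cc1ccc(CCCN/C(N)=N/C(=O)CC(c2ccccc2)c2ccccc2)o1` gives 7.03 in a functional assay on Sf9 cells for antagonist activity at histamine H2 receptor (Homo sapiens), with stated times of 2 min and 20 min; a higher number here means a more potent compound, by a factor of ten per unit of this negative logarithm, a lower number a less potent compound
compound 2 `N/C(=N\C(=O)CC(c1ccccc1)c1ccccc1)NCCCn1ccnc1` gives 5.82 in this assay

Compound 2 is the lower of the two values, and the step of a number 1.21 log units lower from compound 1 to compound 2 (beyond the scatter) is large. Compound 3 `N/C(=N\C(=O)CC(c1ccccc1)c1ccccc1)NCCCc1ncc[nH]1` keeps the same atoms, joined differently: 1H-imidazol-2-yl in place of 1H-imidazol-1-yl on a saturated chain carbon, three bonds along the chain from an amine nitrogen. Within the data shown here, no measured step covers this change, since the only step known swaps a different group entirely. Without guidance, the step of a number 0.18 log units higher from compound 2 to compound 3 (within the scatter) is expected to stay within the scatter. Compound 3 is therefore estimated at 6, in a range from 5.3 to 6.7.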

Compound 3, negative logarithm of the antagonist equilibrium constant: 6.13
Compound 3: the middle estimate sits 0.13 log units below what was measured; the measured number falls inside the stated range.
By their numbers in this assay, from the lowest: compound 2; then compound 3; then compound 1.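

Joining the same atoms differently matters at this position: 1H-imidazol-2-yl in place of 1H-imidazol-1-yl gives a number 0.31 log units higher from compound 2 to compound 3 (beyond the scatter) in this assay and adds a hydrogen-bond donor to the ring. Even so, this imidazole does not match the 5-((dimethylamino)methyl)furan-2-yl group, as the change gives a number 0.90 log units lower from compound 1 to compound 3 (beyond the scatter) and remains a modest loss. Nothing available explains why the attachment point changes the number. Still open, as far as these compounds go, is how 1H-imidazol-4-yl would compare on the same propyl chain, and whether a longer chain would bring either imidazole closer to compound 1.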